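Compound 2 to compound 3: a new group on sulfur

The source may report more compounds than this note shows. Statements on the series, on what has been measured and on what is new or still open speak of the compounds shown alone.

Measured in a functional assay on DU-145 cells (Homo sapiens) for inhibition, read by trypan blue exclusion, with a stated time of 96 h (a lower number here means a stronger inhibitor of growth, a higher number a weaker inhibitor of growth), as follows:
- compound 1 `Cc1ccc(S/C(=C/c2cc(Cl)cc(Cl)c2Cl)C(=O)c2ccc(Cl)cc2)cc1` gives 50000 nM as a number
- compound 2 `O=C(/C(=C\c1c(O)cc(O)cc1O)SCc1ccc(Cl)cc1)c1ccc(Cl)cc1` gives > 100000 nM as a limit of the assay

Compound 2 stands at the limit of > 100000 nM in this assay, at which 1 of the 2 values shown sits, and offers a limit only. Compound 3 `Cc1ccc(S/C(=C/c2c(O)cc(O)cc2O)C(=O)c2ccc(Cl)cc2)cc1` has 4-methylphenyl in place of 4-chlorobenzyl on a sulfur and is otherwise the same as compound 2. For the measured compounds named here, no measured pair isolates this change. Going by the values given here, compound 1 gives 50000 nM as the only true number in this assay and the expectation leans on that value. The expected step is an at least 1.6-fold lower number from compound 2 to compound 3 (0.22 log units; that floor lies within the scatter) in the direction of stronger growth inhibition, small and possibly no larger than the scatter. For compound 3 the estimated concentration is 60000 nM with an expected range from 15000 nM to 100000 nM. There is a real chance that compound 3 will yield only a limit of the assay.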

Compound 3, concentration for 50% growth inhibition: > 100000 nM
Compound 3: only a limit was reported; the forecaster's own chance of this, stated with the estimate: 35%; middle value at least 1.6-fold (0.22 log units) from the limit.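

In this assay compound 3 joins compound 2 at a limit of the assay: the limit of > 100000 nM in this assay, at which 2 of the 3 values shown sit.

With both compounds at a limit, the step between them cannot be read, so this series does not separate 4-methylphenyl from 4-chlorobenzyl on a sulfur. For the compounds shown here, the result does give a first one-place comparison on the double-bonded chain carbon: 2,4,6-trihydroxyphenyl in place of 2,3,5-trichlorophenyl gives an at least 2.0-fold higher number from compound 1 to compound 3 (0.30 log units; that floor lies within the scatter), so the change may be no larger than the scatter.

Still open, on these data alone, is whether the group on a sulfur affects growth inhibition at all when the 2,4,6-trihydroxyphenyl group is present. As far as these compounds go, it is also open whether an amine or a carboxylic acid on the sulfur-bound ring would bring compound 3 back to a true number.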